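A few compounds are considered here, and "the series" means these few. Any claim that something is new, unique, unknown or untested is made for them only; others in the source may bear on it.

Among the compounds with values here, in an in vitro functional assay on 1321-N1 cells for agonist activity at Free fatty acid receptor 1 (Homo sapiens), read by fluorescence, spectrophotometry and calcium flux (a higher number here means that more compound is needed for the effect, a lower number that less compound is needed), compound 2, `O=C(O)CCc1ccc(C#Cc2cccs2)cc1`, gives 251 nM, the lowest of the two numbers measured so far. Compound 1, `O=C(O)CCc1ccc(C#Cc2ncccc2[N+](=O)[O-])cc1`, stands at 11000 nM in this assay, a gap beyond the usual scatter. Compound 3, `O=C(O)CCc1ccc(C#Cc2cccnc2)cc1`, has not yet been measured; it carries pyridin-3-yl in place of thiophen-2-yl on a triple-bonded carbon. Within the data shown here, no measured pair shows this change, so its size is open. A loss of potency beyond the scatter is expected, and compound 3 is estimated at 1000 nM in this assay, within a range from 300 nM to 4000 nM. The expected step is a 4.0-fold higher number from compound 2 to compound 3 (0.60 log units; beyond the scatter).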

Compound 3, half-maximal effective concentration: 6030 nM
Estimate against measurement, compound 3: 6.0-fold (0.78 log units) below; the measured number lies above the stated range.
By their numbers in this assay, from the lowest: compound 2; then compounds 3 and 1 (each within the scatter of the next).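

In this assay, pyridin-3-yl in place of thiophen-2-yl on a triple-bonded carbon gives a 24-fold higher number from compound 2 to compound 3 (1.38 log units; beyond the scatter), the first single-place change seen here, and shows that this position does not accept every aromatic ring alike. The change swaps a five-membered ring for a six-membered one and sulfur for nitrogen at once, so the step cannot be assigned to either difference. Nothing measured here explains the loss. Still open, going by these compounds, is whether phenyl would separate ring size from the hetero atom, and whether furan-2-yl would keep the number of compound 2.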